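The source may hold more compounds than are shown below. What is called first, only, known or untested is meant among the compounds shown, and "the series" means these compounds.

Measured compounds in a functional assay on PC-3 cells (Homo sapiens) for cytotoxicity, read by MTT assay, with a stated time of 72 h; a lower number here means a stronger inhibitor, a higher number a weaker inhibitor:
- compound 1 `COc1ccc(-n2ccc(=O)c(C(=O)Nc3ccc(Oc4ccnc5[nH]ccc45)cc3)n2)cc1`: > 60000 nM
- compound 2 `O=C(Nc1ccc(Oc2ccnc3[nH]ccc23)cc1)c1nn(-c2ccc(Br)cc2)ccc1=O`: 8040 nM
- compound 3 `COc1ccc(-n2ccc(=O)c(C(=O)Nc3ccc(Oc4ccnc5[nH]ccc45)c(F)c3)n2)cc1`: 46400 nM

Compound 1 stands at a limit of this assay, not at a number (the limit of > 60000 nM in this assay, at which 1 of the 3 values shown sits). Compound 2 sits at a measured number, and the step of an at least 7.4-fold lower number from compound 1 to compound 2 (0.87 log units; beyond the scatter) is at least modest. The step of an at least 1.2-fold lower number from compound 1 to compound 3 (0.11 log units; that floor lies within the scatter) has a floor that lies within the scatter.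

Compound 4 `COc1ccc(-n2ccc(=O)c(C(=O)Nc3ccc(Oc4ccnc5c4ccn5C)cc3)n2)cc1` differs from compound 1 by methyl in place of hydrogen on an aromatic nitrogen. Among the compounds with values here, neither measured step touches an aromatic nitrogen; both alter carbons of the same aryl rings, so no measured step bears directly on this change. The expected step that the limit leaves unreadable from compound 1 to compound 4 is therefore none beyond the scatter, with compound 4 most likely again reported only as a limit. Compound 4 is estimated at 100000 nM, in the range 40000 nM to 300000 nM.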

Compound 4, half-maximal inhibitory concentration: > 60000 nM
Compound 4: a limit, no number (the forecaster's own chance of this, stated with the estimate: 85%); the middle value does not contradict the limit.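

Within the data shown here, compound 1 and compound 4 both stand at a limit and not at a number, so no step between them can be read: the limit of > 60000 nM in this assay, at which 2 of the 4 values shown sit. The compounds shown leave open what methyl in place of hydrogen on an aromatic nitrogen does in this assay when the parent compound gives a measured number.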